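A few compounds are considered here, and "the series" means these few. Any claim that something is new, unique, unknown or untested is made for them only; others in the source may bear on it.

The study begins with two measured compounds. Compound 1, `CCc1cn([C@H]2C[C@@H]3OP(=O)(O)OC[C@H]3O2)c(=O)[nH]c1=O`, gives 55 ug/mL in a functional assay on L1210 cells (Mus musculus); on this read-out lower numbers stand for stronger inhibition and higher numbers for weaker inhibition. Compound 2, `CCCCCCc1cn([C@H]2C[C@H](O)[C@@H](CO)O2)c(=O)[nH]c1=O`, gives 172 ug/mL in this assay, the highest of the two numbers; compound 1, its nearest neighbour, sits at a lower number, and that gap lies beyond the usual scatter of the assay. Among the measured compounds shown here, no single-point step between measured compounds is available, and the two differ in more than one place, so only their two values can be compared.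

The unmeasured compound 3 is `CCCc1cn([C@H]2C[C@H](O)[C@@H](CO)O2)c(=O)[nH]c1=O`. Against compound 2 the change is this: hydrogen in place of propyl on a saturated chain carbon, three bonds along the chain from an aromatic carbon.

For the measured compounds named here, with no measured step to lean on, the account can only weigh what is seen. Compound 2, carrying the longer chain, stands at the higher number, while compound 1, with a shorter chain and a different sugar, stands lower. A modest move toward a lower number is expected for compound 3, but it may well stay within the scatter. Compound 3 is estimated at 100 ug/mL, with a range of 30 ug/mL to 300 ug/mL; this corresponds to an expected step of a 1.7-fold lower number from compound 2 to compound 3 (0.24 log units; within the scatter).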

Compound 3, concentration for 50% inhibition: > 500 ug/mL
Compound 3: no number, only a limit (the forecaster's own chance of this, stated with the estimate: 10%); at least 5.0-fold (0.69 log units) between middle value and limit.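

In this assay compound 3 reaches only a limit of the assay, > 500 ug/mL, and not a number. Cutting the chain from hexyl to propyl, at the place three bonds along the chain from an aromatic carbon, is a step of an at least 2.9-fold higher number from compound 2 to compound 3 (0.46 log units; beyond the scatter), the first single-place step in the series, and it shows that on this core the shorter chain goes with weaker inhibition, not stronger. That reading rests on a value at the edge of what the assay reports, so it gives a direction and a minimum size rather than a full size: the limit of > 500 ug/mL in this assay, at which 1 of the 3 values shown sits.

From the compounds shown here alone, how far compound 3 lies past its limit stays open, and so does the true size of the step, while compound 1 differs from both in more than one place and cannot place the ethyl chain on this trend. With only hexyl and propyl on this core, the compounds shown do not tell whether a longer chain such as octyl would bring a still lower number, or how a chain ending in an amine or a carboxylic acid would read.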